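Capping the Phenol: From Compound 2 to Compound 4

A few compounds are considered here, and "the series" means these few. Any claim that something is new, unique, unknown or untested is made for them only; others in the source may bear on it.

Three compounds have so far been measured in a functional assay on SH-SY5Y cells (Homo sapiens) for cytotoxicity, read by MTT assay, with stated times of 24 h and 4 h; a higher number here means that more compound is needed for the effect, a lower number that less compound is needed:

Compound 1 `COc1cc(CNC(=O)/C=C/c2ccccc2OCc2nc(C)c(C)nc2C)ccc1OCc1nc(C)c(C)nc1C` gives 6280 nM.
Compound 2 `COc1cc(CNC(=O)/C=C/c2cccc(O)c2)ccc1OCc1nc(C)c(C)nc1C` gives 3680 nM.
Compound 3 `COc1cc(CNC(=O)/C=C/c2cccc(OCc3nc(C)c(C)nc3C)c2)ccc1OCc1nc(C)c(C)nc1C` gives 8700 nM.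

Compound 2 carries the lowest of these three numbers; compound 1 sits within the usual scatter of it, while compound 3 lies beyond that scatter. For the measured compounds named here, the one measured step that touches the free hydroxyl of compound 2 is a 2.4-fold higher number from compound 2 to compound 3 (0.37 log units; beyond the scatter), a modest rise when the hydroxyl is capped with a large group.

Compound 4 `COc1ccc(OC)c(/C=C/C(=O)NCc2ccc(OCc3nc(C)c(C)nc3C)c(OC)c2)c1` has not yet been measured. It differs from compound 2 as follows: 2,5-dimethoxyphenyl in place of 3-hydroxyphenyl on a double-bonded chain carbon bound to a double-bonded chain carbon. The hydroxyl donor disappears and two methoxy groups arrive, so the change again removes the free hydroxyl, though with smaller groups in other places on the ring. Going by the values given here, since the only comparable step, a 2.4-fold higher number from compound 2 to compound 3 (0.37 log units; beyond the scatter), raised the number modestly, a modest rise is expected here too, with wide uncertainty because the positions differ. Compound 4 is therefore estimated at 5500 nM, with a range from 2500 nM to 12000 nM, which means an expected step of a 1.5-fold higher number from compound 2 to compound 4 (0.17 log units; within the scatter).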

Compound 4, half-maximal effective concentration: 11000 nM
Estimate against measurement, compound 4: 2.0-fold (0.30 log units) below, and the stated range covers the measured number.
By their numbers in this assay, from the lowest: compounds 2, 1, 3 and 4 (each within the scatter of the next, the first and the last beyond it).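

In this assay, 2,5-dimethoxyphenyl in place of 3-hydroxyphenyl on a double-bonded chain carbon bound to a double-bonded chain carbon gives a 3.0-fold higher number from compound 2 to compound 4 (0.48 log units; beyond the scatter), so a rise beyond the scatter now appears with two methoxy groups as well as with the large cap of compound 3. Compound 3 and compound 4 both lack the free hydroxyl and both stand beyond the scatter of compound 2, but compound 1 also lacks it and stays within the scatter of compound 2, so losing the hydroxyl does not always go with such a rise. Nothing shown here explains the rise.

As far as these compounds go, removing the hydroxyl and adding two methoxy groups happen in one step, so their separate contributions stay open. A phenyl ring carrying a single methoxy group, or an amine in place of the hydroxyl, would be needed to tell them apart.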